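The source may report more compounds than this note shows. Statements on the series, on what has been measured and on what is new or still open speak of the compounds shown alone.

Working notes on the series. The shared core is that of compound 1 `c1ccc(Oc2ccc3c(NCCCNCc4ccco4)ccnc3c2)cc1`, which in an ADME assay on HepG2 cells (Homo sapiens) for cytotoxicity, read by luminescence, CellTiter-Glo and ATP content, with a stated time of 72 h (a higher number here means that more compound is needed for the effect, a lower number that less compound is needed), gives 15200 nM. Among the measured compounds shown here, two further measured compounds carry changes in more than one place at once, so no single step connects them to compound 1: compound 2 `COc1cccc(CNCCCNc2ccnc3cc(Oc4ccc(Cl)cc4)ccc23)c1O` gives 5700 nM in this assay, and compound 3 `COc1ccc(F)cc1CNCCCNc1ccnc2cc(C3CCCCC3)ccc12` gives 2290 nM in this assay. Compound 1 therefore stands highest of the three numbers; its nearest neighbour is compound 2 and the gap to it lies beyond the scatter, while the gap to compound 3 is wider still. Only the values of these pairs can be compared, since each differs from compound 1 in several places.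

The unmeasured compound 4 `CC(C)CCc1ccc2c(NCCCNCc3ccco3)ccnc2c1` differs from compound 1 in one place: isopentyl in place of phenoxy on an aromatic carbon. Both compounds that sit below compound 1 lack the phenoxy group, though they also carry other changes, so the direction of the step in this assay is uncertain. A moderate move to a lower number is expected, a 1.9-fold lower number from compound 1 to compound 4 (0.28 log units; within the scatter), but it may not exceed the scatter. In this assay compound 4 is estimated at 8000 nM, within a range from 3000 nM to 22000 nM.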

Compound 4, half-maximal effective concentration: 11200 nM
For compound 4 the middle estimate is 1.4-fold (0.15 log units) below the measured one; the range from low to high includes it.
By their numbers in this assay, from the lowest: compound 3; then compounds 2, 4 and 1 (each within the scatter of the next, the first and the last beyond it).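

Among the compounds shown here, replacing phenoxy with isopentyl on this aromatic carbon gives a 1.4-fold lower number from compound 1 to compound 4 (0.13 log units; within the scatter) in this assay, the first step that isolates a single place. At this position, exchanging phenoxy with its aromatic ring and oxygen for an open carbon chain does not separate the two compounds, so the step offers no support for reading phenoxy alone as what sets compound 1 apart from the other compounds in this assay. No measured data on hand bear on what underlies this result.

For the compounds shown here, only two groups have been compared at this position on this core, so it remains open whether a group of another kind, such as an amine, a carboxylic acid or a longer chain, would move the number beyond the scatter. From the compounds shown here alone, it is also open whether the same exchange would stay this small when the side chain of compound 1 is replaced by those of compound 2 or compound 3.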